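From 2-bromobenzyl to 3-fluorobenzyl on the amide

This account rests on a few compounds, and the source may have more. Where it says the series, first, only, none or still open, it means among the compounds named here.

Measured in a functional assay on A2780 cells (Homo sapiens) for antiproliferative activity, read by resazurin assay, with a stated time of 72 h; on this read-out higher numbers stand for weaker inhibition and lower numbers for stronger inhibition
Compound 1 `Cc1cccc(Cc2n[nH]c3cc(O)c(C(=O)N(C)Cc4ccccc4)cc23)c1` gives 490 nM
Compound 2 `Cc1cccc(Cc2n[nH]c3cc(O)c(C(=O)N(C)Cc4ccccc4Br)cc23)c1` gives 310 nM

Among the measured compounds shown here, compound 2 stands level with compound 1, the only other measured compound, since the two values lie within the scatter of each other. Compound 3 `Cc1cccc(Cc2n[nH]c3cc(O)c(C(=O)N(C)Cc4cccc(F)c4)cc23)c1` awaits measurement in this assay and differs from compound 2 by 3-fluorophenyl in place of 2-bromophenyl on a saturated chain carbon bound to an amide-type nitrogen in one place: 3-fluorophenyl in place of 2-bromophenyl on a saturated chain carbon bound to an amide-type nitrogen. For the measured compounds named here, one measured step bears on this, the bromo in place of hydrogen on an aromatic carbon, which gave a 1.6-fold lower number from compound 1 to compound 2 (0.20 log units; within the scatter) and so stayed small. Going by the values given here, no measured compound carries 3-fluorophenyl, so the direction is open and no shift beyond the scatter is expected. The expected change is a 1.3-fold higher number from compound 2 to compound 3 (0.11 log units; within the scatter) in this estimate. For compound 3 the estimated value is 400 nM with an expected range of 180 nM to 900 nM in this assay.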

Compound 3, half-maximal inhibitory concentration: 440 nM
For compound 3 the middle estimate is 1.1-fold (0.04 log units) below the measured one; measured number inside the range.
By their numbers in this assay, from the lowest: compounds 2, 3 and 1 (each within the scatter of the next).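

In this assay, putting 3-fluorophenyl in place of 2-bromophenyl gave a 1.4-fold higher number from compound 2 to compound 3 (0.15 log units; within the scatter), and adding a fluoro group to the benzyl group on the amide gave a 1.1-fold lower number from compound 1 to compound 3 (0.05 log units; within the scatter), so both new steps lie within the scatter. Compound 3 thus adds a second halogen-bearing benzyl group on the amide, and compounds 1, 2 and 3 stand level, whether that group carries no halogen, bromo or fluoro. No supporting measurement is available to explain this outcome.

From the compounds shown here alone, because the halogen and its location on the ring change together from compound 2 to compound 3, the effect of each alone remains open. Going by these compounds, it also remains open whether an amine or a carboxylic acid on the benzyl ring, or a longer chain in place of benzyl, would move the number beyond the scatter.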